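Swapping Methyl for Fluoro on the Benzyl Arm

The source may hold more compounds than are shown below. What is called first, only, known or untested is meant among the compounds shown, and "the series" means these compounds.

Measured compounds, read in an ADME assay on L929 cells (Mus musculus) for antiproliferative activity, read by CCK-8 assay, with a stated time of 48 h; on this read-out lower numbers stand for stronger inhibition and higher numbers for weaker inhibition:
- compound 1 `CC(C)CSc1n[nH]c(-n2[se]c3ccccc3c2=O)n1` gives 33400 nM
- compound 2 `CCCCCCSc1n[nH]c(-n2[se]c3ccccc3c2=O)n1` gives 39300 nM
- compound 3 `Cc1ccc(CSc2n[nH]c(-n3[se]c4ccccc4c3=O)n2)cc1` gives > 50000 nM, which is a limit of the assay and not a number

All three share the same core and differ only in the group on the saturated chain carbon bound to sulfur. Compound 3 sits at the limit of > 50000 nM in this assay, at which 1 of the 3 values shown sits, so its true value is not pinned down; it is only known to be no stronger than that limit.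

The measured steps are all small: a 1.2-fold higher number from compound 1 to compound 2 (0.07 log units; within the scatter); an at least 1.4-fold higher number from compound 1 to compound 3 (0.17 log units; that floor lies within the scatter); an at least 1.2-fold higher number from compound 2 to compound 3 (0.10 log units; that floor lies within the scatter). None of them moves the read-out beyond the scatter, even though each swaps the whole group at that position.

Compound 4 `O=c1c2ccccc2[se]n1-c1nc(SCc2ccc(F)cc2)n[nH]1` differs from compound 3 by fluoro in place of methyl on an aromatic carbon. This change is smaller than any of the measured swaps, which themselves left the number essentially unchanged, so no step beyond the scatter is expected in this assay, in either direction. Compound 4 is therefore expected to remain at or near the limit, with an expected step that the limit leaves unreadable from compound 3 to compound 4. The estimate for compound 4 is 55000 nM, with a range from 25000 nM to 120000 nM.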

Compound 4, half-maximal inhibitory concentration: > 50000 nM
Compound 4: only a limit was reported (the forecaster's own chance of this, stated with the estimate: 60%); the middle value lies beyond the limit too.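

In this assay, the 4-fluorobenzyl arm of compound 4 ends at the same limit of the assay as the 4-methylbenzyl arm of compound 3, so a second ring substituent at this position has now failed to give a number inside the assay's range: the limit of > 50000 nM in this assay, at which 2 of the 4 values shown sit.

The step between these two compounds cannot be read, so the change from methyl to fluoro has no measurable size here, and nothing can be said about its direction. Against the two compounds with saturated chains only floors are available, an at least 1.2-fold higher number from compound 2 to compound 4 (0.10 log units; that floor lies within the scatter) and an at least 1.4-fold higher number from compound 1 to compound 4 (0.17 log units; that floor lies within the scatter), so compound 4 is not shown to differ from either of them.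

On these data alone, how far compound 3 and compound 4 really lie past the limit remains open, and so does the question of whether the 4-fluorobenzyl and 4-methylbenzyl arms truly differ from the saturated chains. An amine or a carboxylic acid at the same ring position, or a plain benzyl arm with only hydrogen there, could show whether this ring position can bring the number back within the assay's range at all.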